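The source may hold more compounds than are shown below. What is called first, only, known or untested is meant among the compounds shown, and "the series" means these compounds.

Compound 1 `COc1ccccc1N1CCN(C(=O)CCc2c(-c3ccc(Cl)cc3)[nH]c3ccccc23)CC1` is the weaker of two compounds measured in an assay on CHO cells for displacement of a labelled ligand from Substance-P receptor (Homo sapiens) (on this read-out lower numbers stand for stronger inhibition and higher numbers for weaker inhibition), where compound 1 gives 31 nM. Compound 2 `COc1ccccc1N1CCN(C(=O)CCc2c(-c3ccccc3)[nH]c3ccc(Cl)cc23)CC1` gives 5.6 nM in this assay, and the gap between the two lies beyond the scatter of this kind of measurement. Compound 3 `COc1ccccc1N1CCN(C(=O)CCc2c(-c3ccc(Cl)cc3)[nH]c3cccc(Cl)c23)CC1` is compound 1 with a single change: chloro in place of hydrogen on an aromatic carbon. Within the data shown here, no directly comparable step is available among the measured compounds, so the outcome is uncertain. A modest shift toward stronger binding, a 2.1-fold lower number from compound 1 to compound 3 (0.32 log units; beyond the scatter), is expected, partly because compound 2 reaches 5.6 nM. Compound 3 is therefore estimated at 15 nM, within 4 nM to 60 nM.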

Compound 3, half-maximal inhibitory concentration: 950 nM
Compound 3: middle estimate off by 63-fold (1.80 log units), on the low side; measured number outside the range, above it.
By their numbers in this assay, from the lowest: compound 2; then compound 1; then compound 3.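

Putting chloro in place of hydrogen on this aromatic carbon, ortho to a fused ring, brings a 31-fold higher number from compound 1 to compound 3 (1.49 log units; beyond the scatter) in this assay and so a large step toward weaker binding. A single added heavy atom at this place is therefore enough to cost much of the binding seen for compound 1. No measurement shown gives a reason for this loss. From the compounds shown here alone, whether fluoro, methyl or an amine on this same carbon would shift the number as far remains open.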